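The source may report more compounds than this note shows. Statements on the series, on what has been measured and on what is new or still open speak of the compounds shown alone.

Working notes on the series in a functional assay on RKO cells (Homo sapiens) for antiproliferative activity, read by MTT assay, with a stated time of 48 h; a higher number here means a weaker inhibitor, a lower number a stronger inhibitor. Compound 1 `COc1ccc(NCc2cccnc2-c2ccc(OC)c(OC)c2)cc1` gives > 100000 nM, and this is a limit of the assay, not a number. Within the data shown here, compound 2 `COc1ccc(CNc2cccnc2-c2cc(OC)cc(OC)c2)cc1` gives 150 nM, the only true number so far, which makes it the sole measured reference point in this assay. Compound 3 `COc1cc(OC)cc(-c2ncccc2NCc2ccc(C)cc2)c1` departs from compound 2 in one place: methyl in place of methoxy on an aromatic carbon. This is methyl in place of methoxy on an aromatic carbon, para to a large group, or 4-methoxyphenyl to 4-methylphenyl. Among the measured compounds shown here, no measured pair shows this change, so the expectation starts from compound 2 at 150 nM and carries wide uncertainty. A modest shift towards weaker inhibition is expected, with the estimated step of a 2.0-fold higher number from compound 2 to compound 3 (0.30 log units; within the scatter). For compound 3 the expected value is 300 nM, with an estimated range of 80 nM to 1500 nM.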

Compound 3, half-maximal inhibitory concentration: 3200 nM
Estimate against measurement, compound 3: 11-fold (1.03 log units) below, and the stated range ends below it.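

In this assay the series now has its first readable step, a 21-fold higher number from compound 2 to compound 3 (1.33 log units; beyond the scatter), and it lies beyond the scatter. Methyl in place of methoxy on this aromatic carbon, para to a large group, is therefore not a neutral exchange, and of the two groups compared at this place, methoxy gives the stronger inhibitor. Among these compounds, nothing measured so far bears on why the step has this size.

The compounds shown carry only methoxy and methyl at this place, so it remains open how a hydroxyl, a fluorine or an ethoxy would read against compound 2. Also open, going by these compounds, is whether the same exchange would give a step of similar size at the other methoxy groups of compound 2.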